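Aryl swap on the spiro series: compound 3 to compound 4

The source may hold more compounds than are shown below. What is called first, only, known or untested is meant among the compounds shown, and "the series" means these compounds.

Measured compounds:
compound 1 `CC1=NN(c2ccccc2)C(=O)[C@]12C(=O)C=CC[C@H]2c1ccccc1[N+](=O)[O-]`, 11200 nM
compound 2 `CC1=NN(c2ccccc2)C(=O)[C@]12C(=O)C=CC[C@H]2c1ccc(C)cc1`, 4220 nM
compound 3 `CC1=NN(c2ccccc2)C(=O)[C@]12C(=O)C=CC[C@H]2c1cccc(C)c1`, 9580 nM

In a functional assay on HCT-116 cells (Homo sapiens) for inhibition, read by MTT assay, with a stated time of 72 h (on this read-out higher numbers stand for weaker inhibition and lower numbers for stronger inhibition), compound 3 stands second highest of the three numbers, within the scatter of compound 1 and separated from compound 2 by a 2.3-fold higher number from compound 2 to compound 3 (0.36 log units; beyond the scatter). Compound 4 `COc1ccccc1[C@@H]1CC=CC(=O)[C@]12C(=O)N(c1ccccc1)N=C2C` brings the change (2-methoxyphenyl in place of 3-methylphenyl on a saturated ring carbon). Among the compounds with values here, the steps that bear on it are a 1.2-fold lower number from compound 1 to compound 3 (0.07 log units; within the scatter), which shows that the 2-nitrophenyl member and compound 3 are indistinguishable, and a 2.7-fold lower number from compound 1 to compound 2 (0.42 log units; beyond the scatter), the only change beyond scatter in the set. With nothing in the data tying a 2-methoxyphenyl to either outcome, the expected step is a 1.0-fold higher number from compound 3 to compound 4 (0.02 log units; within the scatter), no change beyond the scatter. For compound 4 the estimate in this assay is 10000 nM, with a range from 4000 nM to 25000 nM.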

Compound 4, half-maximal inhibitory concentration: 2850 nM
Compound 4: the middle estimate sits 3.5-fold (0.55 log units) above what was measured, outside the stated range (below it).
By their numbers in this assay, from the lowest: compounds 4 and 2 (each within the scatter of the next); then compounds 3 and 1 (each within the scatter of the next).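

In this assay the aryl group on this saturated ring carbon moves the number beyond the scatter even from the level shared by the 3-methylphenyl and 2-nitrophenyl members, with a 3.4-fold lower number from compound 3 to compound 4 (0.53 log units; beyond the scatter) and with a 3.9-fold lower number from compound 1 to compound 4 (0.59 log units; beyond the scatter) for methoxy in place of nitro. A group named at the 2-position of the phenyl therefore does not fix the outcome, while a 1.5-fold lower number from compound 2 to compound 4 (0.17 log units; within the scatter) leaves the 2-methoxyphenyl and 4-methylphenyl groups unseparated. No measurement here accounts for these steps.

Open, as far as these compounds go, is whether 4-methoxyphenyl, an aminophenyl or a carboxylic acid on this phenyl would keep the number at this level or shift it. Also open, from the compounds shown here alone, is whether a longer chain in place of methoxy would do either.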